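The source may hold more compounds than are shown below. What is called first, only, known or untested is meant among the compounds shown, and "the series" means these compounds.

Measured so far:
compound 1 `O=C(Nc1ccccc1)Nc1nnc(Sc2ncnc3scc(-c4ccncc4)c23)s1` gives 19400 nM
compound 2 `Cc1cccc(NC(=O)Nc2nnc(Sc3ncnc4scc(-c5ccncc5)c34)s2)c1` gives 20700 nM

In a functional assay on HepG2 cells (Homo sapiens) for antiproliferative activity, read by MTT assay, with a stated time of 48 h (a higher number here means a weaker inhibitor, a lower number a stronger inhibitor), compound 2 has the higher of the two numbers, but compound 1 sits within the scatter of it, so the two cannot be ranked. Compound 3 `O=C(Nc1cccc(Cl)c1)Nc1nnc(Sc2ncnc3scc(-c4ccncc4)c23)s1` differs from compound 2 by chloro in place of methyl on an aromatic carbon. For the measured compounds named here, the only measured step that touches this part of the molecule is a 1.1-fold higher number from compound 1 to compound 2 (0.03 log units; within the scatter), which put the methyl there without effect beyond the scatter. The swap to chloro is therefore expected to give no step beyond the scatter, a 1.0-fold lower number from compound 2 to compound 3 (0.01 log units; within the scatter). Compound 3 is estimated at 20000 nM, with a range from 9000 nM to 45000 nM.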

Compound 3, half-maximal inhibitory concentration: 22900 nM
Compound 3: middle estimate off by 1.1-fold (0.06 log units), on the low side; low and high end bracket the measured number.
By their numbers in this assay, from the lowest: compounds 1, 2 and 3 (each within the scatter of the next).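

In this assay, chloro in place of methyl on this aromatic carbon leaves the number within the scatter (a 1.1-fold higher number from compound 2 to compound 3 (0.04 log units; within the scatter)), and so does chloro in place of hydrogen (a 1.2-fold higher number from compound 1 to compound 3 (0.07 log units; within the scatter)). The earlier compounds shown here showed this only for methyl, so now two different groups at this place, 3-methylphenyl and 3-chlorophenyl, cannot be told apart from the plain phenyl of compound 1. No other measurement is at hand that bears on this result.
On these data alone, whether an amine or a carboxylic acid at this place would move the number beyond the scatter stays open. So does the effect of chloro elsewhere on this ring.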